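Dichlorophenyl in Place of Hydroxynaphthyl on Ehrlich Cell Cytotoxicity

The source may hold more compounds than are shown below. What is called first, only, known or untested is meant among the compounds shown, and "the series" means these compounds.

Measured so far:
compound 1 `COc1cc(N2C(N)=C(C#N)C(c3c(OC)ccc4ccccc34)C3=C2CC(C)(C)CC3=O)cc(OC)c1OC`; in a functional assay on Ehrlich cells (Mus musculus) for cytotoxicity, tested at 10 ug/mL (on this read-out lower numbers stand for a weaker effect and higher numbers for a stronger effect at the one concentration tested), compound 1 gives 0%
compound 2 `COc1cc(N2C(N)=C(C#N)C(c3c(O)ccc4ccccc34)C3=C2CC(C)(C)CC3=O)cc(OC)c1OC`; in this assay compound 2 gives 2%

Among the measured compounds shown here, compound 2 holds the higher of the two numbers, but its only neighbour, compound 1, lies within the scatter of it, so no order between the two can be read. For the measured compounds named here, the single measured step, a number 2 percentage points higher from compound 1 to compound 2 (within the scatter), moved the read-out by nothing beyond the scatter, and both compounds sit near the bottom of the scale in this assay.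

Compound 3 `COc1cc(N2C(N)=C(C#N)C(c3ccc(Cl)cc3Cl)C3=C2CC(C)(C)CC3=O)cc(OC)c1OC` differs from compound 2 by 2,4-dichlorophenyl in place of 2-hydroxynaphthalen-1-yl on a saturated ring carbon. Going by the values given here, no measured step bears on this exchange: the one step available concerns hydrogen in place of methyl on an oxygen on an aromatic ring, a different change altogether, and it stayed within the scatter. With nothing in the measured pair pointing either way, the step from compound 2 to compound 3 in this assay is expected to be a number 1 percentage points higher from compound 2 to compound 3 (within the scatter), that is, none beyond the scatter. Compound 3 is therefore estimated at 3%, with a range from 0% to 15%.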

Compound 3, a percentage reported as activity, at one concentration (the size of the read-out at that concentration, not a potency): 20%
The estimate for compound 3 lay 17 percentage points below the measured number; the measured number lies above the stated range.
By their numbers in this assay, from the lowest: compounds 1 and 2 (each within the scatter of the next); then compound 3.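

At the saturated ring carbon next to the ring atom that bears a cyano group, the choice of aromatic group proved able to shift the read-out in this assay: 2,4-dichlorophenyl in place of 2-hydroxynaphthalen-1-yl gave a number 18 percentage points higher from compound 2 to compound 3 (beyond the scatter) and in place of 2-methoxynaphthalen-1-yl gave a number 20 percentage points higher from compound 1 to compound 3 (beyond the scatter). Among the compounds shown here, the earlier step changed only the group on the naphthalene oxygen and stayed within the scatter, whereas exchanging the whole aromatic group is the first change here to go beyond it, and it does so against both naphthalene compounds. Nothing available accounts for this rise, so it cannot be assigned to the chlorines or to the loss of the second aromatic ring.

The compounds shown leave open whether the chlorines matter at all, since a plain phenyl or a 4-chlorophenyl at this carbon would separate their part from that of the exchange of two aromatic rings for one. Also open, as far as these compounds go, is whether other halogens or a methoxy group on the phenyl ring would give a similar number, and how compound 3 would behave at other concentrations.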